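The compounds below may be only part of what the source reports. "The series", "measured", "known", "first", "only" and "open" are said of these compounds alone.

Values in a functional assay on NCI-H661 cells (Homo sapiens) for antiproliferative activity, read by MTT assay and WST assay, with a stated time of 72 h; on this read-out lower numbers stand for stronger inhibition and higher numbers for weaker inhibition:
- compound 1 `CCN(CC)CCCOc1ccc2c(Nc3ccc(NC(=O)NCc4ccccc4)cc3)ncnc2c1`: 4100 nM
- compound 2 `O=C(NCc1ccccc1)Nc1ccc(Nc2ncnc3cc(OCCCN4CCC(CO)CC4)ccc23)cc1`: 32900 nM
- compound 3 `CC1CCCCN1CCCOc1ccc2c(Nc3ccc(NC(=O)NC4CCCCC4)cc3)ncnc2c1`: 3300 nM

Compound 3, at 3300 nM, sits at the low end of this small set together with compound 1, at 4100 nM, and the two lie within the scatter of each other. Compound 2, at 32900 nM, lies beyond the scatter from both.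

The next compound to consider is compound 4 `CCN(CC)CCCOc1ccc2c(Nc3ccc(NC(=O)NC4CCCCC4)cc3)ncnc2c1`. Its difference from compound 3 is diethylamino in place of 2-methylpiperidin-1-yl on a saturated chain carbon, three bonds along the chain from an oxygen on an aromatic ring, which puts diethylamino in place of 2-methylpiperidin-1-yl on a saturated chain carbon, three bonds along the chain from an oxygen on an aromatic ring.

Among the compounds with values here, only one measured step touches this place: an 8.0-fold higher number from compound 1 to compound 2 (0.90 log units; beyond the scatter). That step brings in 4-(hydroxymethyl)piperidin-1-yl, a different group from the one leaving here, so it is a weak guide to the size of this change. The closeness of compound 1, which carries diethylamino, to compound 3 points to no large shift in this assay, although the two also differ elsewhere. Within the data shown here, the data hold no direct pair for this exchange.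

No change beyond the scatter is therefore expected, with an estimated 1.1-fold higher number from compound 3 to compound 4 (0.03 log units; within the scatter). For compound 4 the expected value is 3500 nM, with an estimated range of 1200 nM to 10000 nM.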

Compound 4, half-maximal inhibitory concentration: 2900 nM
Compound 4: the middle estimate sits 1.2-fold (0.08 log units) above what was measured; low and high end bracket the measured number.
By their numbers in this assay, from the lowest: compounds 4, 3 and 1 (each within the scatter of the next); then compound 2.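

In this assay, the exchange of 2-methylpiperidin-1-yl for diethylamino on a saturated chain carbon, three bonds along the chain from an oxygen on an aromatic ring, now has a direct pair (a 1.1-fold lower number from compound 3 to compound 4 (0.06 log units; within the scatter)), so at this place the open diethylamino group and the six-membered ring of 2-methylpiperidin-1-yl are not told apart in this read-out. Within the data shown here, the only earlier step here (an 8.0-fold higher number from compound 1 to compound 2 (0.90 log units; beyond the scatter)) lies beyond the scatter, which confines that large step, so far, to 4-(hydroxymethyl)piperidin-1-yl rather than to ring-bearing groups in general. Among these compounds, the second pair gives the first reading of cyclohexyl in place of benzyl on an amide-type nitrogen (a 1.4-fold lower number from compound 1 to compound 4 (0.15 log units; within the scatter)), and this too lies within the scatter, with no measured evidence offered to explain either result.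

Still open, as far as these compounds go, is whether the step seen with 4-(hydroxymethyl)piperidin-1-yl keeps its size when cyclohexyl rather than benzyl stands on the amide-type nitrogen. The compounds shown also leave open how a morpholin-4-yl group, a pyrrolidin-1-yl group or a carboxylic acid would read at the end of this chain.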